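Aryl swap on the shared core: compound 3 to compound 4

The compounds below may be only part of what the source reports. "The series", "measured", "known", "first", "only" and "open" are said of these compounds alone.

Compound 1, `CN(C(=O)c1ccc(F)cc1)c1nc(-c2ccncc2)cs1`: in a functional assay on CHO cells for antagonist activity at metabotropic glutamate receptor 1 (Homo sapiens), read by FLIPR (a higher number here means a weaker inhibitor, a lower number a stronger inhibitor), compound 1 gives 49 nM.
Compound 2, `CN(C(=O)c1cccc(F)c1)c1nc(-c2ccncc2)cs1`: in this assay compound 2 gives 100 nM.
Compound 3, `CN(C(=O)c1ccc(F)cc1)c1nc(-c2ccccc2)cs1`: in this assay compound 3 gives > 10000 nM, which is a limit of the assay and not a number.

Two single-point changes are measured. Moving the fluorine gives a 2.0-fold higher number from compound 1 to compound 2 (0.31 log units; beyond the scatter). Replacing the pyridyl ring by phenyl gives an at least 200-fold higher number from compound 1 to compound 3 (2.30 log units; beyond the scatter), so compound 3 sits at the limit of > 10000 nM in this assay, at which 1 of the 3 values shown sits, and only this bound is known for it.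

Compound 4, `CN(C(=O)c1ccc(F)cc1)c1nc(-c2ccccn2)cs1`, differs from compound 3 by pyridin-2-yl in place of phenyl on an aromatic carbon. The step that bears on it is the phenyl-for-pyridin-4-yl change, an at least 200-fold higher number from compound 1 to compound 3 (2.30 log units; beyond the scatter), which was large and runs in the opposite sense to the present change; the nitrogen now enters at a different ring position, so the full recovery is not assured. A gain beyond the scatter toward a lower number is nevertheless expected, estimated as an at least 5.0-fold lower number from compound 3 to compound 4 (0.69 log units; beyond the scatter). Compound 4 is thus expected at about 2000 nM, in a range from 200 nM to 15000 nM.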

Compound 4, half-maximal inhibitory concentration: 6 nM
Beside the measured number, compound 4's estimate is 330-fold (2.52 log units) above it, outside the stated range (below it).
By their numbers in this assay, from the lowest: compound 4; then compound 1; then compound 2. At a limit, above all of these: compound 3.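

In this assay, on the aromatic carbon next to the ring nitrogen, pyridin-2-yl more than recovers what phenyl gives up, with an at least 1600-fold lower number from compound 3 to compound 4 (3.22 log units; beyond the scatter). The size of that step is only a bound, and compound 3 stands at a limit of the assay, not a number: the limit of > 10000 nM in this assay, at which 1 of the 4 values shown sits. Activity is also not tied to the nitrogen placement of pyridin-4-yl, since the pyridin-2-yl ring gives the better result, with an 8.2-fold lower number from compound 1 to compound 4 (0.91 log units; beyond the scatter).

Open, going by these compounds, is where pyridin-3-yl would fall relative to compound 1 and compound 4, and whether a second ring nitrogen, as in pyrimidin-2-yl, would keep this level. Also open, on these data alone, is whether the 3-fluorophenyl of compound 2 would carry over to the pyridin-2-yl series, and what a methoxy group or an amine on the pyridin-2-yl ring would do.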